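The source may hold more compounds than are shown below. What is called first, only, known or untested is meant among the compounds shown, and "the series" means these compounds.

Compounds measured so far: compound 1 `N/C(=N\C(=O)NCc1ccccc1)NC1CCc2nc(N)sc2C1`, 513 nM; compound 2 `Cc1nc(N)sc1CCCN/C(N)=N/C(=S)N[C@@H](C)c1ccccc1`, 339 nM; compound 3 `Cc1nc(N)sc1CCCN/C(N)=N/C(=O)NC(C)c1ccc(Cl)cc1`, 46.8 nM.

In an assay on membranes from Sf9 cells for displacement of a labelled ligand from histamine H2 receptor (Homo sapiens), read by scintillation counting, with a stated time of 60 min (on this read-out lower numbers stand for stronger inhibition and higher numbers for weaker inhibition), compound 3 gives the lowest of the three numbers, with compound 2 a step beyond the scatter above it and compound 1 further still. Compound 4 `Cc1nc(N)sc1CCCN/C(N)=N/C(=O)NC(C)c1ccco1` is not yet measured. It differs from compound 3 in one place: furan-2-yl in place of 4-chlorophenyl on a saturated chain carbon bound to an amide-type nitrogen and a saturated chain carbon. Within the data shown here, no step between measured compounds separates this pair, so the gap must be judged from the two values alone once the second is known. The change is expected to cost potency, a step of moderate size beyond the scatter, a 3.2-fold higher number from compound 3 to compound 4 (0.51 log units; beyond the scatter), because compound 3 sits at 46.8 nM and the other measured compounds all lie higher. Compound 4 is estimated at 150 nM, in the range 50 nM to 450 nM.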

Compound 4, inhibition constant: 31.6 nM
Estimate against measurement, compound 4: 4.7-fold (0.68 log units) above; measured number below the stated range.
By their numbers in this assay, from the lowest: compounds 4 and 3 (each within the scatter of the next); then compounds 2 and 1 (each within the scatter of the next).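

In this assay, furan-2-yl in place of 4-chlorophenyl on the saturated chain carbon gives a 1.5-fold lower number from compound 3 to compound 4 (0.17 log units; within the scatter), so the two groups cannot be told apart at this position. A five-membered aromatic ring with one hetero atom serves here as well as the larger chlorinated six-membered ring, and neither the chlorine nor the six-membered ring is needed to keep the number at this level. No measurement shown explains this result. Going by these compounds, it remains open whether a non-aromatic group such as cyclohexyl, or an amine, would be tolerated at this position.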